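Replacing the 4-methyl-2-oxopyrrolidin-1-yl group of compound 1

The compounds below may be only part of what the source reports. "The series", "measured", "known", "first", "only" and "open" are said of these compounds alone.

In a physicochemical assay for solubility, read by LC-MS, in phosphate buffer, with a stated time of 24 h, at pH 7.4 (on this read-out lower numbers stand for lower solubility and higher numbers for higher solubility), compound 1 `C[C@@H]1CC(=O)N(c2cnc(NCc3c(F)ccc4c3CCO4)n3cnnc23)C1` gives 130000 nM, the highest of the two actual numbers available. Compound 3 `CN(C)Cc1ccc2c(c1)CN(c1cnc(NCc3c(F)ccc4c3CCO4)n3cnnc13)C2=O` gives 12000 nM, lower than compound 1 by a gap beyond the scatter. Compound 2 `CC(=O)N1CCC(c2cnc(NCc3c(F)ccc4c3CCO4)c3cn[nH]c(=O)c23)CC1` is reported only as a limit, < 2000 nM.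

Compound 4 `CN(C(=O)c1ccccc1)c1cnc(NCc2c(F)ccc3c2CCO3)n2cnnc12` has not yet been measured. It carries benzoyl(methyl)amino in place of 4-methyl-2-oxopyrrolidin-1-yl on an aromatic carbon. Among the measured compounds shown here, no two measured compounds differ in one place only, so the guidance for this assay is indirect. Like compound 4, compound 3 has a six-membered aromatic ring of carbon only in the group at that place, and compound 3 stands at 12000 nM. On that single comparison, a downward step beyond the scatter is expected, and the estimated step is a 4.3-fold lower number from compound 1 to compound 4 (0.64 log units; beyond the scatter). The solubility expected for compound 4 is 30000 nM, with an estimated range of 6000 nM to 110000 nM.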

Compound 4, solubility: 280000 nM
Compound 4: the middle estimate sits 9.3-fold (0.97 log units) below what was measured, outside the stated range (above it).
By their numbers in this assay, from the lowest: compound 3; then compound 1; then compound 4. At a limit, below all of these: compound 2.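

Compound 1 and compound 4 form the only pair shown that differs in one place, and in this assay the change gives a 2.2-fold higher number from compound 1 to compound 4 (0.33 log units; beyond the scatter). At this aromatic carbon, therefore, a non-aromatic five-membered ring can give way to the larger benzoyl(methyl)amino, with its six-membered aromatic ring of carbon only, and the number still rises, though modestly and on this single pair. Nothing measured here accounts for the step.

Because the change replaces the whole group at once, the compounds shown do not separate the effect of opening the lactam from that of adding the aromatic ring. They also leave open what would happen with a piperazine or a carboxylic acid on that ring, or with a longer chain in place of the methyl on the amide nitrogen.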